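Butyl in Place of sec-Butyl: What Compound 4 Might Show

The source may hold more compounds than are shown below. What is called first, only, known or untested is meant among the compounds shown, and "the series" means these compounds.

Compound 2 `CCC(C)n1cnc2c(NCc3ccc(C(=O)Nc4ccccc4N)cc3)nc(Cl)nc21` stands second highest of the three numbers measured in a functional assay on NCI-H460 cells (Homo sapiens) for antiproliferative activity, read by CCK-8 assay, with a stated time of 72 h, tested at 8 uM (a lower number here means a weaker effect, a higher number a stronger effect of the compound at the concentration tested), where compound 2 gives 67.7%. Above it, compound 3 `Cc1ccc(Nc2nc(Cl)nc3c2ncn3Cc2ccc(C(=O)Nc3ccccc3N)cc2)cc1` gives 82.5%; below it, compound 1 `COC(CCn1cnc2c(NCc3ccc(C(=O)Nc4ccccc4N)cc3)nc(Cl)nc21)OC` gives 51.2%. Going by the values given here, the one step between directly comparable compounds, a number 16.5 percentage points higher from compound 1 to compound 2 (beyond the scatter), came with sec-butyl in place of 3,3-dimethoxypropyl on an aromatic nitrogen, a change larger than the scatter.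

Compound 4 `CCCCn1cnc2c(NCc3ccc(C(=O)Nc4ccccc4N)cc3)nc(Cl)nc21` has not yet been measured in this assay. It differs from compound 2 in one place: butyl in place of sec-butyl on an aromatic nitrogen. Among the compounds with values here, no measured step bears directly on this exchange of one four-heavy-atom chain for another at the same aromatic nitrogen; the only measured step there swapped an entirely different group. With the same atoms merely joined differently, and no evidence of a shift, the expected step is small. Compound 4 is therefore estimated to give about 65%, within a range from 50% to 80%. The expected step of a number 2.7 percentage points lower from compound 2 to compound 4 (within the scatter) is estimated to remain within the scatter.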

Compound 4, a percentage reported as inhibition, at one concentration (the size of the read-out at that concentration, not a potency): 23.7%
Compound 4: the middle estimate sits 41.3 percentage points above what was measured; the whole stated range lies above it.
By their numbers in this assay, from the lowest: compound 4; then compound 1; then compound 2; then compound 3.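

In this assay, butyl in place of sec-butyl on the aromatic nitrogen came with a number 44 percentage points lower from compound 2 to compound 4 (beyond the scatter), showing that the number at this position depends strongly on how the same four carbons are joined, which the earlier step between two quite different groups could not show. Ethyl in place of dimethoxymethyl on a saturated chain carbon, two bonds along the chain from an aromatic nitrogen, came with a number 27.5 percentage points lower from compound 1 to compound 4 (beyond the scatter), so the dimethoxymethyl end of the chain goes with the higher number in this pair. Nothing available explains either step.

Going by these compounds, it remains open whether the higher number of compound 2 extends to other branched groups at this nitrogen, such as isopropyl or tert-butyl. Equally open, on these data alone, is how a longer chain, such as hexyl, or a chain ending in an amine would compare with butyl.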